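The source may report more compounds than this note shows. Statements on the series, on what has been measured and on what is new or still open speak of the compounds shown alone.

Working notes on the series. Two compounds have been run in a functional assay on the whole organism (blood, strain Charles Foster/Wistar albino) with Rattus norvegicus as the target, with a stated time of 30 min, at a dose of 100 mg/kg by the oral route (a higher number here means more inhibition at the dose given (going by the name of the read-out), a lower number less inhibition), so far. Compound 1 `CCN(CC)CCCOc1cc(OC)ccc1-c1cc(-c2ccccc2)no1` gives 14.3% in this assay. Compound 2 `COc1ccc(-c2cc(-c3ccccc3)no2)c(OCCCN2CCCCC2)c1` gives 20.8% in this assay; of the two numbers shown it is the one at the top, but the only other number, that of compound 1, lies within the scatter of it. Compound 3 `CCOC(=O)CCCOc1cc(OC)ccc1-c1cc(-c2ccccc2)no1` has not been measured. Its structural change from compound 2 is ethoxycarbonyl in place of piperidin-1-yl on a saturated chain carbon, three bonds along the chain from an oxygen on an aromatic ring. Among the measured compounds shown here, the one measured step at the same place, a number 6.5 percentage points higher from compound 1 to compound 2 (within the scatter), was small. For the measured compounds named here, no measured pair carries an ethoxycarbonyl group, so that step bears on the new compound only indirectly, and no step beyond the scatter is expected in this assay. The estimate for compound 3 is 17%, with a range from 4% to 32%. The step this estimate implies, a number 3.8 percentage points lower from compound 2 to compound 3 (within the scatter), is expected to stay within the scatter.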

Compound 3, a percentage reported as inhibition, in the whole organism at one dose (the size of the read-out at that dose, not a potency): 4.6%
Compound 3: middle estimate off by 12.4 percentage points, on the high side; measured number inside the range.
By their numbers in this assay, from the lowest: compounds 3, 1 and 2 (each within the scatter of the next, the first and the last beyond it).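

In this assay, the place three bonds along the chain from an oxygen on an aromatic ring now shows a change that can be read: ethoxycarbonyl in place of piperidin-1-yl gives (a number 16.2 percentage points lower from compound 2 to compound 3 (beyond the scatter)). Ethoxycarbonyl in place of diethylamino gives (a number 9.7 percentage points lower from compound 1 to compound 3 (within the scatter)), so the change away from a ring-free amine stays unresolved, and the effect of replacing the amine depends on which of the two amines is the reference. No measurement at hand accounts for the step.

Going by these compounds, whether the larger step belongs to amines at this chain end in general remains open, as only the piperidin-1-yl comparison passes the scatter. Also open, on these data alone, is how a morpholin-4-yl group, a free carboxylic acid or a longer chain would read at this place.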